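Replacing the Hydroxyethyl Chain: What Compound 4 May Show

The source may hold more compounds than are shown below. What is called first, only, known or untested is meant among the compounds shown, and "the series" means these compounds.

The values below come from a functional assay on G-361 cells (Homo sapiens) for cytotoxicity, read by fluorescence, with a stated time of 72 h; on this read-out higher numbers stand for weaker inhibition and lower numbers for stronger inhibition.

- compound 1 `CC(C)c1n[nH]c2c(NCc3ccc(-c4ccccn4)cc3)nc(NCCO)nc12` gives 39 nM
- compound 2 `CC(C)c1n[nH]c2c(NCc3ccc(-c4ccccn4)cc3)nc(N[C@@H]3CCCC[C@H]3N)nc12` gives 477 nM
- compound 3 `CC(C)c1n[nH]c2c(NCc3ccc(-c4ccccn4)cc3)nc(N[C@H]3CC[C@H](N)CC3)nc12` gives 745 nM

Among the compounds with values here, of these three numbers, the one for compound 1 is the lowest, and its steps to the other two lie beyond the scatter. Compound 4 `CC(C)c1n[nH]c2c(NCc3ccc(-c4ccccn4)cc3)nc(NCc3ccc(-c4ccccn4)cc3)nc12` has not yet been measured. It departs from compound 1 as follows: 4-(pyridin-2-yl)phenyl in place of hydroxymethyl on a saturated chain carbon bound to a nitrogen on an aromatic ring. In words, 4-(pyridin-2-yl)phenyl stands in place of hydroxymethyl on a saturated chain carbon bound to a nitrogen on an aromatic ring.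

Two measured steps replace the same 2-hydroxyethyl group with a ring-bearing substituent. The first is a 12-fold higher number from compound 1 to compound 2 (1.09 log units; beyond the scatter), and the second is a 19-fold higher number from compound 1 to compound 3 (1.28 log units; beyond the scatter). Both are large and point the same way. The two aminocyclohexyl isomers themselves stay close, with a 1.6-fold higher number from compound 2 to compound 3 (0.19 log units; within the scatter). Within the data shown here, none of the measured compounds carries an aromatic group at this place, so the transfer to compound 4 is uncertain. A higher number than that of compound 1 is still expected in this assay, of roughly the same size as these two steps. The expected change is a 9.0-fold higher number from compound 1 to compound 4 (0.95 log units; beyond the scatter). For compound 4 the estimated value is 350 nM, with an expected range from 70 nM to 2000 nM.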

Compound 4, half-maximal inhibitory concentration: 3610 nM
Beside the measured number, compound 4's estimate is 10-fold (1.01 log units) below it, outside the stated range (above it).
By their numbers in this assay, from the lowest: compound 1; then compounds 2 and 3 (each within the scatter of the next); then compound 4.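

Within the data shown here, with a 93-fold higher number from compound 1 to compound 4 (1.97 log units; beyond the scatter), the exchange reaches further than the earlier steps suggested: in this assay compound 4 gives 3610 nM, while compound 2 gives 477 nM and compound 3 gives 745 nM, so 4-(pyridin-2-yl)phenyl on this saturated chain carbon bound to a nitrogen on an aromatic ring gives the highest number of the four. The earlier compounds shown here showed only aminocyclohexyl groups at this place, and compound 4 adds the first aromatic example, which shows that this position does not tolerate every large group equally in this cell read-out and that two aromatic rings here give the weakest inhibition of the set. No measurement shown here explains why the number rises so far.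

The compounds shown leave open whether the rise follows from the 12 heavy atoms of the entering group, from its aromatic rings, or from the loss of the hydrogen-bond donor that hydroxymethyl carries. A plain phenyl, or a 4-(pyridin-2-yl)phenyl bearing a hydroxyl or an amine, would be needed at this place to pull these apart, and a longer chain ending in hydroxyl would show how much room the chain of compound 1 has.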